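Fluorine position in acylhydrazide sulfonamides: working notes

The source may report more compounds than this note shows. Statements on the series, on what has been measured and on what is new or still open speak of the compounds shown alone.

Compound 1 `O=C(NNC(=O)c1ccccc1F)c1ccc(NS(=O)(=O)c2cnc(O)nc2O)cc1` and compound 2 `O=C(NNC(=O)c1ccc(NS(=O)(=O)c2cnc(O)nc2O)cc1)c1ccc(F)cc1` share one core, and compound 2 differs from compound 1 by 4-fluorophenyl in place of 2-fluorophenyl on a carbonyl carbon. In a functional assay on OVCAR-3 cells (Homo sapiens) for antiproliferative activity, read by MTT assay, with a stated time of 24 h (on this read-out higher numbers stand for weaker inhibition and lower numbers for stronger inhibition), compound 1 gives 16000 nM. Compound 2 reaches only a limit of this assay, > 20000 nM. The measured step is therefore a floor: an at least 1.2-fold higher number from compound 1 to compound 2 (0.09 log units; that floor lies within the scatter). Compound 3 `O=C(NNC(=O)c1ccccc1NS(=O)(=O)c1cnc(O)nc1O)c1ccccc1F` stands on a different core; the difference between the two cores is not broken down here. In this assay compound 3 gives 15300 nM, close to compound 1. Compound 4 `O=C(NNC(=O)c1ccccc1NS(=O)(=O)c1cnc(O)nc1O)c1ccc(F)cc1` differs from compound 3 by 4-fluorophenyl in place of 2-fluorophenyl on a carbonyl carbon, the same change as from compound 1 to compound 2. For compound 4 a step of a 1.4-fold higher number from compound 3 to compound 4 (0.16 log units; within the scatter) is expected, resting on an at least 1.2-fold higher number from compound 1 to compound 2 (0.09 log units; that floor lies within the scatter), which is itself only a floor. Compound 4 is estimated at 22000 nM, between 14000 nM and 40000 nM.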

Compound 4, half-maximal inhibitory concentration: 15100 nM
Compound 4: the middle estimate sits 1.5-fold (0.16 log units) above what was measured; the range from low to high includes it.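

In this assay the change from 2-fluorophenyl to 4-fluorophenyl on a carbonyl carbon gives a 1.0-fold lower number from compound 3 to compound 4 (0.01 log units; within the scatter). On this second core the change thus shows no step beyond the scatter, but the earlier step gives only a floor, so the data show neither that the change carries over between the cores nor that it does not: the same change on two cores in this assay, an at least 1.2-fold higher number (0.09 log units; that floor lies within the scatter) from compound 1 to compound 2 and a 1.0-fold lower number (0.01 log units; within the scatter) from compound 3 to compound 4; the limit leaves it open whether they differ. The value of compound 2 is a limit and not a number: the limit of > 20000 nM in this assay, at which 1 of the 4 values shown sits.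

The compounds shown leave open whether any substituent at this site moves the number beyond the scatter. Unsubstituted phenyl, or a methoxy group or an amine on that phenyl ring in place of fluorine, would bear on this.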